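Phenyl substitution on the shared core: expectation for compound 4

A few compounds are considered here, and "the series" means these few. Any claim that something is new, unique, unknown or untested is made for them only; others in the source may bear on it.

The series keeps one core and varies the phenyl ring attached to it. Compound 1 `c1ccc(-c2cn3ccnc3c(-c3ccc4ncn(C5CCCCC5)c4c3)n2)cc1` gives 65.7% in a functional assay on UACC-62 cells (Homo sapiens) for inhibition, read by sulforhodamine B assay, with a stated time of 48 h, tested at 10 uM; a higher number here means more inhibition at the concentration tested (going by the name of the read-out), a lower number less inhibition. Compound 2 `COc1ccccc1-c1cn2ccnc2c(-c2ccc3ncn(C4CCCCC4)c3c2)n1` gives 25.1% in this assay, and compound 3 `Fc1ccccc1-c1cn2ccnc2c(-c2ccc3ncn(C4CCCCC4)c3c2)n1` gives 38.2%. Compound 3 thus holds the second highest of the three numbers: a number 27.5 percentage points lower from compound 1 to compound 3 (beyond the scatter) separates it from compound 1, and a number 13.1 percentage points higher from compound 2 to compound 3 (beyond the scatter) from compound 2.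

Compound 4 `FC(F)(F)c1cccc(-c2cn3ccnc3c(-c3ccc4ncn(C5CCCCC5)c4c3)n2)c1` is the next member; the change from compound 3 is 3-(trifluoromethyl)phenyl in place of 2-fluorophenyl on an aromatic carbon. For the measured compounds named here, no measured step exchanges a fluorophenyl for a trifluoromethylphenyl, so the only steps that bear on it are those that alter the phenyl ring: a number 40.6 percentage points lower from compound 1 to compound 2 (beyond the scatter) and a number 27.5 percentage points lower from compound 1 to compound 3 (beyond the scatter), both lowering the number in this assay. Going by the values given here, with only two such changes, no rule can be claimed, but each lowered the number. A further change of this kind is expected to hold compound 4 at or somewhat below compound 3; the expected step is a number 8.2 percentage points lower from compound 3 to compound 4 (within the scatter). Compound 4 is estimated at 30% in this assay, within a range from 10% to 55%.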

Compound 4, a percentage reported as inhibition, at one concentration (the size of the read-out at that concentration, not a potency): 4.33%
Beside the measured number, compound 4's estimate is 25.7 percentage points above it, and the stated range ends above it.
By their numbers in this assay, from the lowest: compound 4; then compound 2; then compound 3; then compound 1.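

In this assay the 3-(trifluoromethyl)phenyl group sits lowest of the four, with a number 33.9 percentage points lower from compound 3 to compound 4 (beyond the scatter) and a number 20.8 percentage points lower from compound 2 to compound 4 (beyond the scatter) and a number 61.4 percentage points lower from compound 1 to compound 4 (beyond the scatter). All three substituted phenyl rings now fall below the unsubstituted phenyl of compound 1 with no compound against this, so among these four compounds the loss is not confined to the 2-fluorophenyl and 2-methoxyphenyl groups. Nothing at hand bears on why the number falls.

On these data alone, compound 4 differs from compound 2 and compound 3 in both the group and its place on the phenyl ring, so the contribution of each remains open. Also open, as far as these compounds go, is whether an amine or a carboxylic acid on the phenyl ring would keep the number near that of compound 1 or lower it as well.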